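The compounds below may be only part of what the source reports. "The series", "measured", "known", "first", "only" and "open" are said of these compounds alone.

Compound 1 `Cc1cc(C(F)(F)F)ccc1C(=O)NC1(c2ccccc2)CCCN(C)C1` and compound 2 `COc1cc(C(F)(F)F)cc(SC)c1C(=O)NC1(c2ccc(F)cc2)CCCN(C)C1` share the same core and differ in the groups attached to it. Within the data shown here, in an assay on cells for inhibition of sodium- and chloride-dependent glycine transporter 1 (Homo sapiens) (a lower number here means that less compound is needed, a higher number that more compound is needed for the effect), compound 2 gives 26 nM, the lowest of the two numbers measured so far, while compound 1 gives 320 nM, a higher number that lies beyond the usual scatter. Compound 3 `COc1cc(C(F)(F)F)cc(SC)c1C(=O)NC1(c2ccncc2)CCCN(C)C1` carries pyridin-4-yl in place of 4-fluorophenyl on a saturated ring carbon. Among the measured compounds shown here, no measured pair shows this exchange, so only a modest move toward a higher number is expected. Compound 3 is estimated at 80 nM, with a range from 25 nM to 250 nM. This expectation means a step of a 3.1-fold higher number from compound 2 to compound 3 (0.49 log units; beyond the scatter).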

Compound 3, half-maximal effective concentration: 60 nM
Beside the measured number, compound 3's estimate is 1.3-fold (0.12 log units) above it, and the stated range covers the measured number.
By their numbers in this assay, from the lowest: compound 2; then compound 3; then compound 1.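

Among these compounds, this is the first change that can be read on its own: with the rest of the molecule unchanged, pyridin-4-yl in place of 4-fluorophenyl on the saturated ring carbon gives a 2.3-fold higher number from compound 2 to compound 3 (0.36 log units; beyond the scatter). The aromatic ring at this position can therefore contain a nitrogen atom at only a modest cost in the number. Nothing available explains the size or direction of this step.

Going by these compounds, the exchange removes the fluorine and adds the ring nitrogen together, so their separate contributions remain unknown. On these data alone, how a pyridin-3-yl or a cyclohexyl ring would behave at this position also remains open.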